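A Pyridinyl Swap at the Limit of Detection

The compounds below may be only part of what the source reports. "The series", "measured", "known", "first", "only" and "open" are said of these compounds alone.

Compound 1 `CCOc1n[nH]c2ncc(C#Cc3c(F)ccc(NS(=O)(=O)c4cccnc4)c3F)cc12` carries an ethoxy group on the shared core. In a functional assay on HCT-116 cells (Homo sapiens) for antiproliferative activity, read by MTT assay, with a stated time of 68 h (on this read-out lower numbers stand for stronger inhibition and higher numbers for weaker inhibition), compound 1 gives 10000 nM. Compound 2 `O=S(=O)(Nc1ccc(F)c(C#Cc2cnc3[nH]nc(-c4ccccc4)c3c2)c1F)c1cccnc1` has a phenyl in its place. In this assay compound 2 gives > 10000 nM, which is a limit of the assay and not a number. The step of a number no lower from compound 1 to compound 2 (the limit leaves the size open) is therefore of unknown size, as the limit of > 10000 nM in this assay, at which 1 of the 2 values shown sits, shows. On these data alone, compound 2 thus stands at the limit, and its standing relative to compound 1 stays open. Compound 3 `O=S(=O)(Nc1ccc(F)c(C#Cc2cnc3[nH]nc(-c4ccncc4)c3c2)c1F)c1cccnc1` differs from compound 2 by the change (pyridin-4-yl in place of phenyl on an aromatic carbon). For the measured compounds named here, no measured step covers this exchange; the single known step, from ethoxy to phenyl, only reached the limit and so offers no direction for the pyridin-4-yl. The expectation for compound 3 is a step of a number no higher from compound 2 to compound 3 (the limit leaves the size open), within the scatter. Compound 3 is estimated at 10000 nM, between 3000 nM and 30000 nM, with a real chance that again only a limit is reported.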

Compound 3, half-maximal inhibitory concentration: > 10000 nM
Compound 3: no number, only a limit (the forecaster's own chance of this, stated with the estimate: 60%); the middle value lies on the limit itself.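

Compound 3, like compound 2, stands at a limit of the assay and not at a number, so the step from compound 2 to compound 3 cannot be read. The other new step is a number no lower from compound 1 to compound 3 (the limit leaves the size open). On this aromatic carbon, the exchange of phenyl for pyridin-4-yl brings a ring nitrogen and a hydrogen-bond acceptor, yet in this assay it still yields no number. The new result therefore adds a second aromatic ring at this position that ends the same way, and most of the series now sits at the ceiling: the limit of > 10000 nM in this assay, at which 2 of the 3 values shown sit.

On these data alone, how far compound 2 and compound 3 lie past the limit stays open, so neither can be ranked against the other. Also open, as far as these compounds go, is whether an amine or a carboxylic acid at this place would give a readable value stronger than that of compound 1.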